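Readings Around a Shared Core, and One Open Step

This account rests on a few compounds, and the source may have more. Where it says the series, first, only, none or still open, it means among the compounds named here.

Compound 1 `CCn1c(C(=O)NCCC(=O)OC)ccc1C(CC)(CC)c1ccc(C#CC(O)(CC)CC)c(C)c1` gives 36300 nM
Compound 2 `C#CCCOC(=O)c1ccc(C(CC)(CC)c2ccc(C#CC(O)(CC)CC)c(C)c2)n1CC` gives > 50000 nM
Compound 3 `CCn1c(C(=O)On2nnc3ccccc32)ccc1C(CC)(CC)c1ccc(C#CC(O)(CC)CC)c(C)c1` gives > 50000 nM

In a functional assay on PC-3 cells (Homo sapiens) for antiproliferative activity, read by MTT assay, with a stated time of 72 h (a lower number here means a stronger inhibitor, a higher number a weaker inhibitor), compound 1 is the only one of the three with a number (36300 nM). Compound 3 reads > 50000 nM and this is a limit, not a number. Compound 2 also gives only a limit (> 50000 nM). Thus the series sits largely at the limit of > 50000 nM in this assay, at which 2 of the 3 values shown sit, for now.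

Compound 4 `CCCCC(=O)c1ccc(C(CC)(CC)c2ccc(C#CC(O)(CC)CC)c(C)c2)n1CC` differs from compound 3 by a group of 4 heavy atoms (4 carbon; no ring) in place of a group of 10 heavy atoms (6 carbon, 3 nitrogen, 1 oxygen; one five-membered aromatic ring with 3 hetero atoms, one six-membered aromatic ring of carbon only), on a carbonyl carbon and is still to be measured. Within the data shown here, three measured steps bear on this change, all altering what the carbonyl carbon carries. They are an at least 1.3-fold higher number from compound 1 to compound 2 (0.13 log units; that floor lies within the scatter) and an at least 1.3-fold higher number from compound 1 to compound 3 (0.13 log units; that floor lies within the scatter), with a step that the two limits leave unreadable from compound 2 to compound 3 as the third. None shows a step beyond the scatter, so no large move is expected. The expected change is an at least 1.2-fold lower number from compound 3 to compound 4 (0.09 log units; that floor lies within the scatter) and may not be readable if another limit results. For compound 4 the estimate is 40000 nM, with an expected range from 15000 nM to 60000 nM.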

Compound 4, half-maximal inhibitory concentration: > 50000 nM
Compound 4: a limit, no number (the forecaster's own chance of this, stated with the estimate: 45%); at least 1.2-fold (0.09 log units) between middle value and limit.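

In this assay compound 4 also gives only a limit, not a number, so a butyl with no hydrogen-bond donors or acceptors on the carbonyl carbon yields no readable value either: the limit of > 50000 nM in this assay, at which 3 of the 4 values shown sit. Among these compounds, the one readable step, an at least 1.3-fold higher number from compound 1 to compound 4 (0.13 log units; that floor lies within the scatter), does not separate the two compounds. The steps from compound 2 and from compound 3 to compound 4 cannot be read, as both ends are limits, but butyl now joins (but-3-yn-1-yl)oxy and the two-ring group of compound 3 in giving no number at this carbonyl carbon.

From the compounds shown here alone, it remains open whether any group at this place reads clearly better than compound 1 at 36300 nM. The compounds shown do not tell what an amine, a carboxylic acid or a longer chain on this carbonyl carbon would give.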